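Swapping an Ester for an Ether on the Core

The compounds below may be only part of what the source reports. "The series", "measured", "known", "first", "only" and "open" are said of these compounds alone.

Compound 1: `CCCCCCc1c(F)c(N)c2c(=O)cc(-c3ccc(N)c(F)c3)oc2c1F`
Compound 2: `CCOC(=O)c1c(F)c(N)c2c(=O)cc(-c3ccc(N)c(F)c3)oc2c1F`
Compound 3, not yet measured: `CCCOCc1c(F)c(N)c2c(=O)cc(-c3ccc(N)c(F)c3)oc2c1F`

In a functional assay on MCF7 cells (Homo sapiens) for cytotoxicity, read by neutral red uptake, with a stated time of 3 days (on this read-out lower numbers stand for stronger inhibition and higher numbers for weaker inhibition), compound 1 gives only a limit of the assay, > 10000 nM. In this assay, among the compounds with values here, compound 2 gives 1400 nM, the single true number so far. As far as these compounds go, the step of an at least 7.1-fold lower number from compound 1 to compound 2 (0.85 log units; beyond the scatter) rests on that limit (the limit of > 10000 nM in this assay, at which 1 of the 2 values shown sits), so its full size is unknown. Compound 3 differs from compound 2 by propoxymethyl in place of ethoxycarbonyl on an aromatic carbon. Within the data shown here, no measured step involves propoxymethyl, so the only guide is the hexyl to ethoxycarbonyl step, which was at least modest. Propoxymethyl lacks the carbonyl of ethoxycarbonyl and, like hexyl, is mostly a carbon chain, so some move back toward the weaker end is expected, most likely a higher number, a 2.9-fold higher number from compound 2 to compound 3 (0.46 log units; beyond the scatter), with wide uncertainty. Compound 3 is therefore estimated at 4000 nM, between 1200 nM and 12000 nM.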

Compound 3, half-maximal inhibitory concentration: 1200 nM
Beside the measured number, compound 3's estimate is 3.3-fold (0.52 log units) above it; the range from low to high includes it.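

In this assay, propoxymethyl in place of ethoxycarbonyl gives a 1.2-fold lower number from compound 2 to compound 3 (0.07 log units; within the scatter), so at this position the carbonyl, with its double bond and second hydrogen-bond acceptor, is not required to keep compound 2's level of activity. Propoxy in place of pentyl gives an at least 8.3-fold lower number from compound 1 to compound 3 (0.92 log units; beyond the scatter), which shows that an ether oxygen in the chain goes with a clear gain over hexyl even with no carbonyl present. That step starts from a limit, so its full size is unknown: the limit of > 10000 nM in this assay, at which 1 of the 3 values shown sits.

Hexyl differs from both other groups in more than its oxygen, so the compounds shown cannot say whether the oxygen itself or the shape of the chain matters. A plain butyl chain, a hydroxymethyl group or a carboxylic acid at this position would each test a different part of that question.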